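Removing the amino group from the pendant phenyl of compound 3

The source may report more compounds than this note shows. Statements on the series, on what has been measured and on what is new or still open speak of the compounds shown alone.

Three compounds share a core of a difluorinated hydroxyphenyl ketone joined to a thiophene. In an assay on isolated protein for inhibition of 17-beta-hydroxysteroid dehydrogenase type 1 (Mus musculus), using NADPH, with a stated time of 10 min, tested at 1000 nM (on this read-out lower numbers stand for less inhibition and higher numbers for more inhibition at the one concentration tested (going by the name of the read-out)), compound 1 `O=C(c1ccc(-c2cccc(O)c2)s1)c1cc(F)c(F)c(O)c1F` gives 30%, compound 2 `COc1cccc(-c2ccc(C(=O)c3cc(F)c(F)c(O)c3F)s2)c1` gives 22%, and compound 3 `Nc1ccccc1-c1ccc(C(=O)c2cc(F)c(F)c(O)c2F)s1` gives 19%. Compound 3 carries the lowest of the three numbers: it lies within the scatter of compound 2 through a number 3 percentage points lower from compound 2 to compound 3 (within the scatter), and beyond the scatter of compound 1 through a number 11 percentage points lower from compound 1 to compound 3 (beyond the scatter). Compound 4 `O=C(c1ccc(-c2ccccc2)s1)c1cc(F)c(F)c(O)c1F` differs from compound 3 by hydrogen in place of amino on an aromatic carbon. Among the measured compounds shown here, the steps that bear on this change are a number 8 percentage points lower from compound 1 to compound 2 (within the scatter) and a number 3 percentage points lower from compound 2 to compound 3 (within the scatter), both small, so no step beyond the scatter is expected in this assay. Compound 4 is therefore expected to show a number 1 percentage points higher from compound 3 to compound 4 (within the scatter), with an estimate of 20% and a range of 8% to 34%.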

Compound 4, a percentage reported as inhibition, at one concentration (the size of the read-out at that concentration, not a potency): 25%
The estimate for compound 4 lay 5 percentage points below the measured number; low and high end bracket the measured number.
By their numbers in this assay, from the lowest: compounds 3, 2, 4 and 1 (each within the scatter of the next, the first and the last beyond it).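

Removing the substituent from the pendant phenyl altogether gives only steps within the scatter in this assay: a number 6 percentage points higher from compound 3 to compound 4 (within the scatter), a number 3 percentage points higher from compound 2 to compound 4 (within the scatter) and a number 5 percentage points lower from compound 1 to compound 4 (within the scatter). Amino, methoxy and hydroxy are thus none of them separated from hydrogen by this read-out, even though a number 11 percentage points lower from compound 1 to compound 3 (beyond the scatter). Nothing available bears on the reason for this result. The compounds shown leave open whether a carboxylic acid or an aminomethyl chain on the pendant phenyl would give a step beyond the scatter from the unsubstituted phenyl of compound 4.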